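Spiro quinoline amide series: pyridyl in place of chlorophenyl

The source may hold more compounds than are shown below. What is called first, only, known or untested is meant among the compounds shown, and "the series" means these compounds.

Measured compounds:
- compound 1 `Cc1ccc(-c2cc(C(=O)N3CCC4(CC3)CC(=O)c3nn(C(C)(C)C)cc3O4)c3ccccc3n2)cc1` gives in a functional assay on MDA-MB-231 cells (Homo sapiens) for inhibition, read by MTT assay, with a stated time of 72 h (on this read-out lower numbers stand for stronger inhibition and higher numbers for weaker inhibition), a limit, > 10000 nM.
- compound 2 `CC(C)(C)n1cc2c(n1)C(=O)CC1(CCN(C(=O)c3cc(-c4ccc(Cl)cc4)nc4ccccc34)CC1)O2` gives in this assay a limit, > 10000 nM.
- compound 3 `COc1ccc(-c2cc(C(=O)N3CCC4(CC3)CC(=O)c3nn(C(C)(C)C)cc3O4)c3ccccc3n2)cc1OC` gives in this assay 7130 nM.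

Compound 2 stands at the limit of > 10000 nM in this assay, at which 2 of the 3 values shown sit, so its own number is not known; only compound 3 gives a readable value. The step that the two limits leave unreadable from compound 1 to compound 2 runs between two limits and cannot be sized. The step of an at least 1.4-fold lower number from compound 2 to compound 3 (0.14 log units; that floor lies within the scatter) is a floor only, and that floor lies within the scatter.

Compound 4 `CC(C)(C)n1cc2c(n1)C(=O)CC1(CCN(C(=O)c3cc(-c4ccncc4)nc4ccccc34)CC1)O2` carries the change pyridin-4-yl in place of 4-chlorophenyl on an aromatic carbon relative to compound 2. Going by the values given here, no measured step in this set swaps an aryl ring for a six-membered aromatic ring with one hetero atom; the only readable movement is the one from compound 2 to compound 3 toward the 3,4-dimethoxyphenyl, and it sets no size. Nothing in the data therefore argues for a step beyond the scatter in this assay in either direction.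

Compound 4 is expected to stay near the limit, estimated at 12000 nM, within 3000 nM to 40000 nM. The expected step that the limit leaves unreadable from compound 2 to compound 4 is estimated as essentially none, with a fair chance that compound 4 again reports only a limit.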

Compound 4, half-maximal inhibitory concentration: 1650 nM
Beside the measured number, compound 4's estimate is 7.3-fold (0.86 log units) above it, and the stated range ends above it.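

In this assay, the aromatic carbon next to the ring nitrogen proves sensitive to the ring it carries: pyridin-4-yl in place of 4-chlorophenyl gives an at least 6.0-fold lower number from compound 2 to compound 4 (0.78 log units; beyond the scatter), and pyridin-4-yl in place of 4-methylphenyl gives an at least 6.0-fold lower number from compound 1 to compound 4 (0.78 log units; beyond the scatter). Both sizes are floors only, and the true steps may be larger: the limit of > 10000 nM in this assay, at which 2 of the 4 values shown sit. Going by these compounds alone, the one step here between two readable values is a 4.3-fold lower number from compound 3 to compound 4 (0.64 log units; beyond the scatter), which places pyridin-4-yl, the only ring in this set with a hetero atom and a hydrogen-bond acceptor, ahead of the 3,4-dimethoxyphenyl as well.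

The compounds shown do not tell whether the ring nitrogen must sit where it does in pyridin-4-yl, a question that pyridin-3-yl, pyridin-2-yl and unsubstituted phenyl at this carbon would address. From the compounds shown here alone, how far the step can be extended also remains open, for instance with an amino or methoxy group on the pyridine ring, and whether it would carry over to a core other than the shared one is unknown.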